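This account rests on a few compounds, and the source may have more. Where it says the series, first, only, none or still open, it means among the compounds named here.

Compound 3 `CCCc1nc(-c2ccccc2)c(CNCCCN2CCN(c3ccccc3F)CC2)o1` stands second of the three measured compounds in an assay on HEK293 cells for inhibition of Voltage-dependent T-type calcium channel subunit alpha-1G (Homo sapiens), read by fluorescence, tested at 10 uM (a higher number here means more inhibition at the concentration tested (going by the name of the read-out), a lower number less inhibition), where compound 3 gives 54.4%. Compound 1 `CCCc1nc(-c2ccccc2)c(CNCCCN2CCN(c3ccccc3)CC2)o1` gives 43.7%, and compound 2 `CCCc1nc(-c2ccccc2)c(CNCCN2CCN(C(c3ccccc3)c3ccccc3)CC2)o1` gives 71.9%. Compound 4 `CCCc1nc(-c2ccccc2)c(CNCCCN2CCN(c3ccccc3C(F)(F)F)CC2)o1` differs from compound 3 by trifluoromethyl in place of fluoro on an aromatic carbon. Within the data shown here, the only measured step that touches the same spot is a number 10.7 percentage points higher from compound 1 to compound 3 (beyond the scatter), where a fluoro entering on that aromatic carbon raised the inhibition beyond the scatter. Among the measured compounds shown here, exchanging fluoro for the larger trifluoromethyl at the same place is expected to continue in the same direction, though no measured pair shows this exact change, so the expected step of a number 5.6 percentage points higher from compound 3 to compound 4 (within the scatter) is kept modest. Compound 4 is therefore estimated at 60%, within a range from 45% to 75%.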

Compound 4, a percentage reported as inhibition, at one concentration (the size of the read-out at that concentration, not a potency): 45%
Compound 4: the middle estimate sits 15 percentage points above what was measured, within the range that was stated.
By their numbers in this assay, from the lowest: compounds 1, 4 and 3 (each within the scatter of the next, the first and the last beyond it); then compound 2.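

In this assay, trifluoromethyl in place of fluoro gives a number 9.4 percentage points lower from compound 3 to compound 4 (within the scatter), while trifluoromethyl in place of hydrogen gives a number 1.3 percentage points higher from compound 1 to compound 4 (within the scatter). Compound 1 and compound 3 lie beyond the scatter of each other, yet compound 4 lies within the scatter of both. The gain seen with fluoro on this aromatic carbon is therefore not clearly shared by trifluoromethyl.

Going by these compounds, whether a methoxy group, a nitrile or an amine on the same carbon would stand clear of compound 1 remains open. No measurement shown explains these numbers.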